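The source may report more compounds than this note shows. Statements on the series, on what has been measured and on what is new or still open speak of the compounds shown alone.

Compound 1 `COc1ccc(C(=O)c2ccc(OC)c3c2OC(C)(C)C=C3)c(NC(=O)CO)c1` and compound 2 `COc1ccc(C(=O)c2ccc3c(c2)C=CC(C)(C)O3)c(NC(=O)CO)c1` share the ((hydroxymethyl)carbonyl)amino group on different cores; the difference between the two cores is not broken down here. In a functional assay on HCT-8 cells (Homo sapiens) for antiproliferative activity, read by MTT assay, with a stated time of 48 h (on this read-out higher numbers stand for weaker inhibition and lower numbers for stronger inhibition), compound 1 gives 230 nM and compound 2 gives 250 nM, two numbers within the scatter of each other. Compound 3 `COc1ccc(C(=O)c2ccc(OC)c3c2OC(C)(C)C=C3)c(NC(=O)CN)c1` carries the change amino in place of hydroxy on a saturated chain carbon bound to a carbonyl carbon on the core of compound 1, and in this assay compound 3 gives 370 nM, so that a 1.6-fold higher number from compound 1 to compound 3 (0.21 log units; within the scatter). Compound 4 `COc1ccc(C(=O)c2ccc3c(c2)C=CC(C)(C)O3)c(NC(=O)CN)c1` carries the same change, (amino in place of hydroxy on a saturated chain carbon bound to a carbonyl carbon), on the core of compound 2. Because a 1.6-fold higher number from compound 1 to compound 3 (0.21 log units; within the scatter) stayed within the scatter, the step from compound 2 to compound 4 is expected to be of similar size, a 1.6-fold higher number from compound 2 to compound 4 (0.20 log units; within the scatter). Compound 4 is therefore estimated at 400 nM in this assay, between 200 nM and 800 nM.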

Compound 4, half-maximal inhibitory concentration: 490 nM
For compound 4 the middle estimate is 1.2-fold (0.09 log units) below the measured one; the range from low to high includes it.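

In this assay amino in place of hydroxy on a saturated chain carbon bound to a carbonyl carbon gives a 2.0-fold higher number from compound 2 to compound 4 (0.29 log units; within the scatter). The step on the core of compound 2 matches the earlier one on the core of compound 1: the same change on two cores in this assay, a 1.6-fold higher number (0.21 log units; within the scatter) from compound 1 to compound 3 and a 2.0-fold higher number (0.29 log units; within the scatter) from compound 2 to compound 4, 1.2-fold (0.09 log units) apart, within the scatter of two such steps. Each step itself lies within the scatter, so the two cores show that the change carries over without a detectable shift, not that it moves the number, and they say nothing about any further core.

Open, on these data alone, is what a dimethylamino group, a carboxylic acid or a longer chain would do in this place. Also open, as far as these compounds go, is whether the two cores stay level in other cell lines.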